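A Second Chloro on the Ring Bound to Nitrogen

This account rests on a few compounds, and the source may have more. Where it says the series, first, only, none or still open, it means among the compounds named here.

Two compounds from one series share a core and differ only in the aromatic ring held on the amine nitrogen. Compound 1 `CN1CCN(CCCOc2cccc3nc(Nc4ccc(F)c(F)c4)ccc23)CC1` carries a 3,4-difluorophenyl there, and in a functional assay on cells (Panel melanoma (Carcinoma cell lines), Homo sapiens) for inhibition, read by sulforhodamine B assay, with a stated time of 48 h (on this read-out higher numbers stand for lower toxicity in this test and lower numbers for higher toxicity in this test), compound 1 gives 10500 nM. Compound 2 `CN1CCN(CCCOc2cccc3nc(Nc4cccc(Cl)c4)ccc23)CC1` carries a 3-chlorophenyl instead, and in this assay compound 2 gives 6450 nM. That exchange produced a 1.6-fold lower number from compound 1 to compound 2 (0.21 log units; within the scatter), so compound 2 stands beside compound 1 rather than apart from it; the two numbers cannot be told apart by this test.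

Compound 3 `CN1CCN(CCCOc2cccc3nc(Nc4cc(Cl)cc(Cl)c4)ccc23)CC1` has not been measured. Its change from compound 2 is chloro in place of hydrogen on an aromatic carbon. Going by the values given here, no measured step adds a second chloro to this ring; the only step known, a 1.6-fold lower number from compound 1 to compound 2 (0.21 log units; within the scatter), swapped one halogen pattern for another on the same ring and stayed within the scatter. On that slender basis, little movement in this assay is expected, with no clear direction. Compound 3 is therefore estimated at 6000 nM, with a range from 2500 nM to 14000 nM. The expected step is a 1.1-fold lower number from compound 2 to compound 3 (0.03 log units; within the scatter).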

Compound 3, concentration lethal to 50% of the cells: 6620 nM
Compound 3: the middle estimate sits 1.1-fold (0.04 log units) below what was measured; measured number inside the range.
By their numbers in this assay, from the lowest: compounds 2, 3 and 1 (each within the scatter of the next).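

Adding a chloro to the 3-chlorophenyl ring is the first direct test of a second halogen at this position: in this assay the step is a 1.0-fold higher number from compound 2 to compound 3 (0.01 log units; within the scatter) and the two compounds cannot be told apart. The 3,5-dichlorophenyl ring also cannot be separated from the 3,4-difluorophenyl ring, with a 1.6-fold lower number from compound 1 to compound 3 (0.20 log units; within the scatter) and all three compounds shown lie within the scatter of one another, so neither a second chloro nor the placing of two halogens on this ring gives a readable difference here. Nothing is available that would explain why these three rings read alike in the cells.

From the compounds shown here alone, all three rings carry only halogens, so it remains open whether a methoxy group, a nitrile or an amine on the same ring would give a number that stands clearly apart in this assay and could be told from the others. Going by these compounds, it is also open whether a change away from this ring, such as a longer chain on the oxygen of the shared core, would matter more than anything done to the ring itself.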